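The source may report more compounds than this note shows. Statements on the series, on what has been measured and on what is new or still open speak of the compounds shown alone.

Working notes on the series. Compound 1 `C/C(=C\CC/C(C)=C/CC[C@@H]1[C@@]2(C)CCC(=O)C(C)(C)[C@H]2CC[C@@]1(C)O)CC/C=C(\C)C(=O)OCc1cn(-c2ccc(F)cc2)nn1` carries 4-fluorophenyl on an aromatic nitrogen; in a functional assay on DU-145 cells (Homo sapiens) for antiproliferative activity, read by MTT assay, with a stated time of 48 h (on this read-out higher numbers stand for weaker inhibition and lower numbers for stronger inhibition), compound 1 reports only a limit of the assay, > 150000 nM. Compound 2 `C/C(=C\CC/C(C)=C/CC[C@@H]1[C@@]2(C)CCC(=O)C(C)(C)[C@H]2CC[C@@]1(C)O)CC/C=C(\C)C(=O)OCc1cn(C[C@@H]2O[C@H](n3ccc(=O)[nH]c3=O)C[C@H]2O)nn1` bears a different substituent at that position; in this assay compound 2 gives 33100 nM. Compound 3 `C/C(=C\CC/C(C)=C/CC[C@@H]1[C@@]2(C)CCC(=O)C(C)(C)[C@H]2CC[C@@]1(C)O)CC/C=C(\C)C(=O)OCc1cn(-c2ccccc2C)nn1`, with 2-methylphenyl in place of 4-fluorophenyl on an aromatic nitrogen, likewise stands only at a limit of the assay, > 150000 nM. The step that the two limits leave unreadable from compound 1 to compound 3 is therefore not readable, both ends sitting at the limit of > 150000 nM in this assay, at which 2 of the 3 values shown sit. Compound 4 `C/C(=C\CC/C(C)=C/CC[C@@H]1[C@@]2(C)CCC(=O)C(C)(C)[C@H]2CC[C@@]1(C)O)CC/C=C(\C)C(=O)OCc1cn(-c2ccc(C)cc2)nn1` is the next move in the aryl series: 4-methylphenyl in place of 2-methylphenyl on an aromatic nitrogen. Within the data shown here, no measured step bears directly on this change; the only readable comparison is that compound 2 lies at a number while the two aryl-substituted analogues sit at the limit. For compound 4 the expected step that the limit leaves unreadable from compound 3 to compound 4 is none beyond the scatter. Compound 4 is estimated at 200000 nM, in the range 60000 nM to 700000 nM, most likely reported again only as a limit.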

Compound 4, half-maximal inhibitory concentration: > 150000 nM
Compound 4 gave a limit, no number; the forecaster's own chance of this, stated with the estimate: 75%; the middle value lies beyond the limit too.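

Compound 4 gives only a limit of the assay and no number, as do compound 1 and compound 3, so no step among these three can be read: the limit of > 150000 nM in this assay, at which 3 of the 4 values shown sit.

The compounds shown leave open whether 4-fluorophenyl, 2-methylphenyl and 4-methylphenyl differ at all in this assay.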